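Changing one group on the shared core

The compounds below may be only part of what the source reports. "The series", "measured", "known", "first", "only" and "open" are said of these compounds alone.

Compound 1 `CC(C)(C)OC(=O)Nc1ccc(NC(=O)CCc2cccc3c2B(O)OC3)cc1`: > 100000 nM
Compound 2 `CC(C)(C)OC(=O)NCc1ccc(NC(=O)CCc2cccc3c2B(O)OC3)cc1`: 2000 nM

Among the measured compounds shown here, in a functional assay on SK-OV-3 cells (Homo sapiens) for antiproliferative activity, read by MTT assay, with a stated time of 72 h (on this read-out higher numbers stand for weaker inhibition and lower numbers for stronger inhibition), compound 2 gives 2000 nM, the only true number so far. Compound 1 gives > 100000 nM, which is a limit of the assay and not a number.

Compound 3 `O=C(CCc1cccc2c1B(O)OC2)Nc1ccc([N+](=O)[O-])cc1` keeps the shared core, but nitro takes the place of ((tert-butoxycarbonyl)amino)methyl on an aromatic carbon: nitro in place of ((tert-butoxycarbonyl)amino)methyl on an aromatic carbon. For the measured compounds named here, one measured step bears on this change: an at least 50-fold lower number from compound 1 to compound 2 (1.69 log units; beyond the scatter). It is large and lies beyond the scatter, and it shows that a change on this aromatic carbon can shift the number strongly. A clear step is therefore expected again, most likely towards a higher number, as only compound 2 has given a true number, 2000 nM. The expected step is a 7.5-fold higher number from compound 2 to compound 3 (0.88 log units; beyond the scatter). For compound 3 the estimated value is 15000 nM, with an expected range from 3000 nM to 80000 nM.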

Compound 3, half-maximal inhibitory concentration: 83000 nM
Beside the measured number, compound 3's estimate is 5.5-fold (0.74 log units) below it, outside the stated range (above it).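

In this assay, replacing ((tert-butoxycarbonyl)amino)methyl with nitro gives a 42-fold higher number from compound 2 to compound 3 (1.62 log units; beyond the scatter), so the low number of compound 2 does not carry over to a group with fewer heavy atoms and no hydrogen-bond donor. Compound 3 gives 83000 nM, a true number. Among the compounds shown here, the value of compound 1 is a limit of the assay and not a number: the limit of > 100000 nM in this assay, at which 1 of the 3 values shown sits. The comparison an at least 1.2-fold lower number from compound 1 to compound 3 (0.08 log units; that floor lies within the scatter) rests on that limit and cannot be read as a real difference, so of the three groups on this aromatic carbon, only the one in compound 2 gives a number well clear of it.

The compounds shown leave open whether a free aminomethyl group or a carboxylic acid at this place would keep the number near that of compound 2. They also leave open whether a longer chain carrying the same carbamate would lower it further.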